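The source may hold more compounds than are shown below. What is called first, only, known or untested is meant among the compounds shown, and "the series" means these compounds.

Compound 1 `CC(C)CNC(=O)[C@H](C)NC(=O)[C@]1(Cc2ccccc2)CCN1C(=O)OCc1ccccc1` — > 100000 nM
Compound 2 `C[C@H](NC(=O)[C@]1(Cc2ccccc2)CCN1C(=O)OCc1ccccc1)C(=O)NC(C)(C)C` — > 100000 nM

Both values shown here are limits of the assay rather than numbers. In an ADME assay on HELF cells (Homo sapiens) for cytotoxicity, with a stated time of 3 days (a lower number here means that less compound is tolerated, a higher number that more compound is tolerated), compound 1 gives > 100000 nM, a limit. Compound 2 likewise reaches only a limit, > 100000 nM. The step that the two limits leave unreadable from compound 1 to compound 2 therefore cannot be read, as the limit of > 100000 nM in this assay, at which 2 of the 2 values shown sit, shows: compound 2 stands at that limit, with no number to place it more closely.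

Compound 3 `C[C@H](NC(=O)[C@]1(Cc2ccccc2)CCN1C(=O)OCc1ccccc1)C(=O)NC1CCCCC1` differs from compound 2 by cyclohexyl in place of tert-butyl on an amide-type nitrogen. Among the measured compounds shown here, the only measured step in this assay bears on a change at the same amide-type nitrogen, but it is unreadable, so it gives neither a size nor a direction. Nothing in the measured data points to a step beyond the scatter, and the expected step of a number no higher from compound 2 to compound 3 (the limit leaves the size open) is therefore none beyond it. Compound 3 is thus expected to remain at the limit, estimated at 100000 nM with a range from 30000 nM to 300000 nM.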

Compound 3, minimum cytotoxic concentration: > 100000 nM
Compound 3 was reported as a limit (the forecaster's own chance of this, stated with the estimate: 75%); the middle value lies on the limit itself.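

Compound 3 also reaches only a limit, so no step among compound 1, compound 2 and compound 3 can be read: the limit of > 100000 nM in this assay, at which 3 of the 3 values shown sit.

The compounds shown leave open whether the groups on the amide-type nitrogen differ at all in this assay.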